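Changing the Hydroxyl Pattern on the Phenyl Group

The source may hold more compounds than are shown below. What is called first, only, known or untested is meant among the compounds shown, and "the series" means these compounds.

Two measured compounds share one core and differ only in the aromatic group on the carbon with a double bond to nitrogen. Compound 1 `COc1ccccc1-c1nnc(-c2ccc(C(=O)N/N=C/c3cccnc3)cc2)o1` carries pyridin-3-yl there, and in an ADME assay on THP-1 cells (Homo sapiens) for cytotoxicity (on this read-out lower numbers stand for stronger inhibition and higher numbers for weaker inhibition), compound 1 gives 167000 nM. Compound 2 `COc1ccccc1-c1nnc(-c2ccc(C(=O)N/N=C/c3c(O)cc(O)cc3O)cc2)o1` carries 2,4,6-trihydroxyphenyl instead, and in this assay compound 2 gives 12400 nM, the lowest of the two numbers measured. For the measured compounds named here, the step of a 13-fold lower number from compound 1 to compound 2 (1.13 log units; beyond the scatter) is the only comparison available. Compound 3 `COc1ccccc1-c1nnc(-c2ccc(C(=O)N/N=C/c3cccc(O)c3O)cc2)o1` has not yet been measured. It differs from compound 2 in one place: 2,3-dihydroxyphenyl in place of 2,4,6-trihydroxyphenyl on a carbon with a double bond to nitrogen. Going by the values given here, no measured step exchanges one hydroxyl pattern for another. Among the compounds with values here, the single step shows only that a hydroxyl-bearing phenyl gave a markedly lower number than pyridin-3-yl. Compound 3 keeps a phenyl with hydroxyl groups. The expected step of a 2.0-fold higher number from compound 2 to compound 3 (0.30 log units; within the scatter) is therefore estimated to be small, toward a somewhat higher number. Compound 3 is expected to give 25000 nM in this assay, within a range from 8000 nM to 80000 nM.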

Compound 3, half-maximal inhibitory concentration: 102000 nM
For compound 3 the middle estimate is 4.1-fold (0.61 log units) below the measured one; the measured number lies above the stated range.
By their numbers in this assay, from the lowest: compound 2; then compounds 3 and 1 (each within the scatter of the next).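

At this carbon with a double bond to nitrogen, a phenyl group carrying hydroxyl groups does not by itself bring the lower number in this assay: exchanging 2,4,6-trihydroxyphenyl for 2,3-dihydroxyphenyl gives a clear change (an 8.2-fold higher number from compound 2 to compound 3 (0.92 log units; beyond the scatter)). The 2,3-dihydroxyphenyl group also cannot be told apart from pyridin-3-yl (a 1.6-fold lower number from compound 1 to compound 3 (0.21 log units; within the scatter)), so among these three groups only 2,4,6-trihydroxyphenyl stands out. No data are available to explain this difference.

Going by these compounds, the two hydroxyl patterns differ in both the number and the places of their hydroxyl groups, so it remains open which of these matters more. Also open, on these data alone, is how a phenyl group with a single hydroxyl, or with an amine or methoxy groups instead, would behave in this assay here.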